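Three Halogens on the Sulfonamide Aryl Ring

The source may report more compounds than this note shows. Statements on the series, on what has been measured and on what is new or still open speak of the compounds shown alone.

Measured so far:
compound 1, `COc1ccc(S(=O)(=O)Nc2cccc(Br)c2)cc1N1CCNCC1`, 1.26 nM
compound 2, `COc1ccc(S(=O)(=O)Nc2cc(Br)cc(Br)c2Cl)cc1N1CCNCC1`, 2.51 nM
compound 3, `COc1ccc(S(=O)(=O)Nc2cc(Br)cc(Cl)c2Br)cc1N1CCNCC1`, 3.98 nM

All three share one core and differ only in the aryl group carried by the sulfonamide nitrogen. In an assay on isolated protein for binding affinity to 5-hydroxytryptamine receptor 6 (Homo sapiens) (a higher number here means a weaker inhibitor, a lower number a stronger inhibitor), compound 1 shows the lowest number of the three; its step to compound 2, a 2.0-fold higher number from compound 1 to compound 2 (0.30 log units; within the scatter), stays within the scatter, while its step to compound 3, a 3.2-fold higher number from compound 1 to compound 3 (0.50 log units; beyond the scatter), goes beyond it. Between compounds 2 and 3 the step of a 1.6-fold higher number from compound 2 to compound 3 (0.20 log units; within the scatter) is again within the scatter.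

Compound 4, `COc1ccc(S(=O)(=O)Nc2cc(Br)cc(F)c2Cl)cc1N1CCNCC1`, has not yet been measured. Compared with compound 1 it carries 5-bromo-2-chloro-3-fluorophenyl in place of 3-bromophenyl on a sulfonamide nitrogen. The nearest measured comparison is compound 2, whose 3,5-dibromo-2-chlorophenyl also carries chlorine and bromine at the same positions, with fluorine in compound 4 standing where compound 2 has its second bromine. Both heavier aryl groups gave higher numbers than compound 1, one within and one beyond the scatter. The step for compound 4 is therefore expected to be small and upward, a 1.7-fold higher number from compound 1 to compound 4 (0.24 log units; within the scatter), and compound 4 is estimated at 2.2 nM, between 1 nM and 5 nM.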

Compound 4, inhibition constant: 3.16 nM
For compound 4 the middle estimate is 1.4-fold (0.16 log units) below the measured one; measured number inside the range.
By their numbers in this assay, from the lowest: compounds 1, 2, 4 and 3 (each within the scatter of the next, the first and the last beyond it).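

The clearest comparison at this position is between compounds that differ by a single halogen: in this assay, fluoro in place of bromo on an aromatic carbon gives a 1.3-fold higher number from compound 2 to compound 4 (0.10 log units; within the scatter) and so does not separate the two compounds. Against the 3-bromophenyl group, the 5-bromo-2-chloro-3-fluorophenyl group gives a 2.5-fold higher number from compound 1 to compound 4 (0.40 log units; beyond the scatter), while the change from the 2,5-dibromo-3-chlorophenyl group gives a 1.3-fold lower number from compound 3 to compound 4 (0.10 log units; within the scatter), so compounds 3 and 4 both stand beyond the scatter from compound 1, with compound 2 the exception among the three-halogen rings. No measurement shown here accounts for these numbers.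

Going by these compounds, every aryl group so far carries only halogens, so it remains open how a ring bearing a methoxy, a nitrile or an amine would behave on the sulfonamide nitrogen in this assay. On these data alone, it is also open which halogen matters most for the difference from compound 1, a question that rings carrying only a chlorine or only a fluorine could help to answer.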